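The source may hold more compounds than are shown below. What is called first, only, known or untested is meant among the compounds shown, and "the series" means these compounds.

Measured so far in a functional assay on Ehrlich cells (Mus musculus) for antiproliferative activity, read by trypan blue exclusion, with a stated time of 2 h, tested at 50 ug/mL; on this read-out lower numbers stand for a weaker effect and higher numbers for a stronger effect at the one concentration tested:
compound 1 `COc1ccc(C2C(C#N)=C(N)N(c3ccc(S(N)(=O)=O)cc3)C3=C2C(=O)CCC3)cc1` – 90%
compound 2 `N#CC1=C(N)N(c2ccc(S(N)(=O)=O)cc2)C2=C(C(=O)CCC2)C1c1cccc([N+](=O)[O-])c1` – 73%

Compound 2 has the lowest of the two numbers in this assay; its nearest neighbour is compound 1, higher by a margin beyond the scatter. Within the data shown here, the one measured step, a number 17 percentage points lower from compound 1 to compound 2 (beyond the scatter), concerns the same saturated ring carbon and is the only point of reference. Compound 3 `N#CC1=C(N)N(c2ccc(S(N)(=O)=O)cc2)C2=C(C(=O)CCC2)C1c1ccc(Cl)cc1Cl` differs from compound 2 as follows: 2,4-dichlorophenyl in place of 3-nitrophenyl on a saturated ring carbon. Among the measured compounds shown here, no measured step involves 2,4-dichlorophenyl, so the direction of the change cannot be read from the data; the one exchange measured on this carbon, a number 17 percentage points lower from compound 1 to compound 2 (beyond the scatter), gives the size of shift that a new group here has produced, and a step no larger than that, in either direction, is the most that can be expected. Compound 3 is therefore estimated at 78% in this assay, with a range of 60% to 95%. The expected step is a number 5 percentage points higher from compound 2 to compound 3 (within the scatter), within the scatter.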

Compound 3, a percentage reported as activity, at one concentration (the size of the read-out at that concentration, not a potency): 65%
Estimate against measurement, compound 3: 13 percentage points above; the range from low to high includes it.
By their numbers in this assay, from the lowest: compounds 3 and 2 (each within the scatter of the next); then compound 1.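

In this assay, the step of a number 8 percentage points lower from compound 2 to compound 3 (within the scatter) shows that 2,4-dichlorophenyl and 3-nitrophenyl on this saturated ring carbon cannot be told apart, although 3-nitrophenyl carries 2 hydrogen-bond acceptors and 2,4-dichlorophenyl carries 0. The step of a number 25 percentage points lower from compound 1 to compound 3 (beyond the scatter) sets a second group clearly apart from 4-methoxyphenyl, so that among the three aryl groups shown, compound 1 alone stands off from the other two at this carbon. No measurement at hand bears on the reason for this result.

Still open, from the compounds shown here alone, is whether the separation of compound 1 stays with other groups on the same phenyl ring, such as 4-hydroxyphenyl or 4-dimethylaminophenyl. Also open, going by these compounds, is whether an aromatic ring is needed on this carbon at all, a question that a cyclohexyl group or a short alkyl chain would address.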